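The source may report more compounds than this note shows. Statements on the series, on what has been measured and on what is new or still open speak of the compounds shown alone.

Among the measured compounds shown here, in a functional assay on EOL1 cells (Homo sapiens) for inhibition, read by fluorescence, with a stated time of 72 h (on this read-out lower numbers stand for stronger inhibition of growth and higher numbers for weaker inhibition of growth), compound 2 `CCCCCCn1cnc2c(Nc3cc(OC)cc(OC)c3)nc(N[C@H]3CC[C@H](N)CC3)nc21` gives 380 nM, the higher of the two numbers measured so far. Compound 1 `CC(C)=CCn1cnc2c(Nc3cccc(Cl)c3)nc(N[C@H]3CC[C@H](N)CC3)nc21` gives 80 nM. The two numbers lie beyond the scatter of each other. Compound 3 `CCCCCCn1cnc2c(Nc3cccc(Cl)c3)nc(N[C@H]3CC[C@H](N)CC3)nc21` carries 3-chlorophenyl in place of 3,5-dimethoxyphenyl on a nitrogen on an aromatic ring. For the measured compounds named here, no measured pair isolates this change, but compound 1 also carries 3-chlorophenyl, at 80 nM. On that ground, a lower number beyond the scatter is expected, with an estimated step of a 2.9-fold lower number from compound 2 to compound 3 (0.47 log units; beyond the scatter). For compound 3 the estimate is 130 nM, with an expected range of 50 nM to 330 nM.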

Compound 3, concentration for 50% growth inhibition: 310 nM
Beside the measured number, compound 3's estimate is 2.4-fold (0.38 log units) below it; low and high end bracket the measured number.
By their numbers in this assay, from the lowest: compound 1; then compounds 3 and 2 (each within the scatter of the next).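

In this assay, 3-chlorophenyl in place of 3,5-dimethoxyphenyl on a nitrogen on an aromatic ring gives a 1.2-fold lower number from compound 2 to compound 3 (0.09 log units; within the scatter) and so does not separate these two compounds. With 3-chlorophenyl held fixed, pentyl in place of 2-methylprop-1-en-1-yl on a saturated chain carbon bound to an aromatic nitrogen gives a 3.9-fold higher number from compound 1 to compound 3 (0.59 log units; beyond the scatter) and so the gap in this series goes with that chain, not with the aromatic group. Nothing measured here accounts for either step. Still open, going by these compounds, is how a benzyl or cyclopentylmethyl group would read in place of that chain.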